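The source may report more compounds than this note shows. Statements on the series, on what has been measured and on what is new or still open speak of the compounds shown alone.

Measured compounds:

compound 1, `Cc1c(Nc2nc(N)c3c(C#N)c(N4CCC[C@H]4C)n(C)c3n2)cnn1C`, with 43 nM in an assay on isolated protein for inhibition of Leucine-rich repeat serine/threonine-protein kinase 2 variant G2019S (Homo sapiens), read by TR-FRET and LanthaScreen, with stated times of 50 min and 30 min, in the presence of a further agent that is not named here; on this read-out higher numbers stand for weaker inhibition and lower numbers for stronger inhibition
compound 2, `Cn1c(N2CCCC2)c(C#N)c2c(N)ncnc21`, with 1910 nM in this assay
compound 3, `Cc1nn(C2COC2)cc1Nc1nc(N)c2c(C#N)c(N3CCC[C@H]3C)n(C)c2n1`, with 25 nM in this assay

Compound 2 stands highest of the three numbers in this assay; compound 1 is the nearest to it, and compound 3 the furthest, and both of those gaps lie beyond the scatter. For the measured compounds named here, the one step that can be read between measured compounds is a 1.7-fold lower number from compound 1 to compound 3 (0.24 log units; within the scatter), which lies within the scatter and concerns a change on the nitrogen on an aromatic ring, not the amine that is at issue here.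

Compound 4, `CN(C)c1c(C#N)c2c(N)ncnc2n1C`, has not been measured. It differs from compound 2 in one place: dimethylamino in place of pyrrolidin-1-yl on an aromatic carbon. Going by the values given here, no measured step bears on this change, since the only measured step, a 1.7-fold lower number from compound 1 to compound 3 (0.24 log units; within the scatter), alters a different part of the molecule. The step from compound 2 to compound 4 is therefore expected to be small, with a 1.3-fold higher number from compound 2 to compound 4 (0.12 log units; within the scatter) lying within the scatter. Compound 4 is estimated to give 2500 nM in this assay, with a range from 1000 nM to 6000 nM.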

Compound 4, half-maximal inhibitory concentration: 3760 nM
Compound 4: middle estimate off by 1.5-fold (0.18 log units), on the low side; measured number inside the range.
By their numbers in this assay, from the lowest: compounds 3 and 1 (each within the scatter of the next); then compounds 2 and 4 (each within the scatter of the next).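

In this assay, replacing pyrrolidin-1-yl with dimethylamino on the aromatic carbon next to the ring nitrogen gives a 2.0-fold higher number from compound 2 to compound 4 (0.29 log units; within the scatter), and this step lies within the scatter. For the compounds shown here, this is the first reading at this position, and it shows that opening the five-membered non-aromatic ring into dimethylamino, which also takes the group from 5 heavy atoms to 3, leaves the two compounds indistinguishable in this measurement, so compound 2 and compound 4 give no sign that the ring matters here. The data offer no measured basis for explaining this result, and the reading speaks only for this pair, on this simple core.

The compounds shown leave open whether a group of a different size at this position, such as an unsubstituted amino group, methylamino or piperidin-1-yl, or one with a further hetero atom, such as morpholin-4-yl, would stay within the scatter of compound 2. They also leave open whether the same replacement would be as quiet on the core of compound 1, which carries a substituted pyrazolyl amine and a methyl group on its pyrrolidine.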